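A few compounds are considered here, and "the series" means these few. Any claim that something is new, unique, unknown or untested is made for them only; others in the source may bear on it.

Compound 1 `O=C(/C=C/c1ccc2c(c1)B(O)OC2)c1ccc(Br)cc1` gives 36700 nM in a toxicity assay on WI-38 cells (Homo sapiens) for cytotoxicity, read by MTT assay, with a stated time of 48 h; a higher number here means a weaker inhibitor, a lower number a stronger inhibitor. Compound 2 `O=C(/C=C/c1ccc2c(c1)B(O)OC2)c1ccc(I)cc1` gives > 100000 nM, which is a limit of this assay rather than a number. Compound 3 `O=C(/C=C/c1ccc2c(c1)B(O)OC2)c1ccc(C(F)(F)F)cc1` gives 22600 nM.

Of the two numbers, compound 3 holds the lowest, and its nearest neighbour is compound 1, with a 1.6-fold lower number from compound 1 to compound 3 (0.21 log units; within the scatter). Against compound 2 there is an at least 4.4-fold lower number from compound 2 to compound 3 (0.64 log units; beyond the scatter), a step that rests on (the limit of > 100000 nM in this assay, at which 1 of the 3 values shown sits). Compound 4 `O=C(/C=C/c1ccc2c(c1)B(O)OC2)c1ccc([N+](=O)[O-])cc1` carries nitro in place of trifluoromethyl on an aromatic carbon. For the measured compounds named here, no measured step exchanges a nitro group; the closest guides are a 1.6-fold lower number from compound 1 to compound 3 (0.21 log units; within the scatter) and an at least 2.7-fold higher number from compound 1 to compound 2 (0.43 log units; beyond the scatter), one within the scatter and one beyond it, both small. Compound 4 is thus expected to move little in this assay, by a 1.2-fold higher number from compound 3 to compound 4 (0.09 log units; within the scatter). The estimate for compound 4 is 28000 nM, with a range from 9000 nM to 90000 nM.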

Compound 4, half-maximal inhibitory concentration: 39300 nM
For compound 4 the middle estimate is 1.4-fold (0.15 log units) below the measured one; the measured number falls inside the stated range.
By their numbers in this assay, from the lowest: compounds 3, 1 and 4 (each within the scatter of the next). At a limit, above all of these: compound 2.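

In this assay, nitro in place of trifluoromethyl on this aromatic carbon brings in hydrogen-bond acceptors, yet the change stays within the scatter: a 1.7-fold higher number from compound 3 to compound 4 (0.24 log units; within the scatter). Nitro in place of bromo likewise stays within it: a 1.1-fold higher number from compound 1 to compound 4 (0.03 log units; within the scatter). Only the iodo group stands apart, with an at least 2.5-fold lower number from compound 2 to compound 4 (0.40 log units; beyond the scatter), a step that rests on a limit rather than a number: the limit of > 100000 nM in this assay, at which 1 of the 4 values shown sits.

On these data alone, whether an amine or a carboxylic acid at this position would stay level with compound 1, compound 3 and compound 4 in this assay remains open. So does the actual number for compound 2, whose entry is only a limit.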